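From Ethyl Ester to Anilide on a Shared Core

A few compounds are considered here, and "the series" means these few. Any claim that something is new, unique, unknown or untested is made for them only; others in the source may bear on it.

The measured compounds:
Compound 1, `CCCSc1nc(Cl)c2c(n1)N(Cc1ccccc1)C(C(=O)N1CCN(C)CC1)N2`, gives 42500 nM in a functional assay on TE-1 cells (Homo sapiens) for antiproliferative activity, read by MTT assay, with a stated time of 72 h; on this read-out higher numbers stand for weaker inhibition and lower numbers for stronger inhibition.
Compound 2, `CCCSc1nc(Cl)c2c(n1)N(Cc1ccccc1)C(C(=O)OCC)N2`, gives > 64000 nM in this assay.

Compound 2 stands at the limit of this assay; its value of the limit of > 64000 nM in this assay, at which 1 of the 2 values shown sits, is a limit and not a number. Going by the values given here, the only measured step, an at least 1.5-fold higher number from compound 1 to compound 2 (0.17 log units; that floor lies within the scatter), goes from a basic amide to an ester and ends at that limit.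

Compound 3, `CCCSc1nc(Cl)c2c(n1)N(Cc1ccccc1)C(C(=O)Nc1ccccc1)N2`, differs from compound 2 by anilino in place of ethoxy on a carbonyl carbon. Among the compounds with values here, no measured step covers the move from an ester to an anilide, so the expectation rests on the two values shown: compound 1 is weak, and compound 2 is at the limit. An amide is restored in compound 3, yet one without the basic ring of compound 1. For compound 3 in this assay an estimated step of an at least 1.2-fold lower number from compound 2 to compound 3 (0.10 log units; that floor lies within the scatter) is expected, a modest move away from the limit, with a real chance that only a limit is again reported. The estimate for compound 3 is 50000 nM, within 15000 nM to 150000 nM.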

Compound 3, half-maximal inhibitory concentration: > 64000 nM
Compound 3: no number, only a limit (the forecaster's own chance of this, stated with the estimate: 45%); middle value at least 1.2-fold (0.10 log units) from the limit.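

The anilide does not move the series off the limit: in this assay compound 3 gives > 64000 nM, which is a limit and not a number, and the step from compound 2 cannot be read, as both of its ends are limits. Replacing 4-methylpiperazin-1-yl with anilino on the same carbonyl carbon gives an at least 1.5-fold higher number from compound 1 to compound 3 (0.17 log units; that floor lies within the scatter), so this floor alone does not separate the two amides. What is new is that an amide at this place does not by itself yield a measured value, since among the three groups shown only 4-methylpiperazin-1-yl gives a number, while the other two share the same limit: the limit of > 64000 nM in this assay, at which 2 of the 3 values shown sit.

Going by these compounds, how far the true values of compound 2 and compound 3 lie past that limit remains unknown, and so does their order relative to each other. Also open, on these data alone, is whether a piperazin-1-yl group without the methyl, a dimethylamino group or a carboxylic acid on this carbonyl carbon would give a number in this assay.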